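Replacing a Carboxyphenylsulfonyl Group with a Piperidinyl Amide

The compounds below may be only part of what the source reports. "The series", "measured", "known", "first", "only" and "open" are said of these compounds alone.

Of the compounds shown here, three sharing one core have been measured in an assay on isolated protein for displacement of a labelled ligand from secreted frizzled-related protein 1 (Homo sapiens), read by fluorescence polarization, with a stated time of 30 min; on this read-out higher numbers stand for weaker inhibition and lower numbers for stronger inhibition. Compound 2 `O=C(O)c1cccc(S(=O)(=O)N2CCC(NS(=O)(=O)c3cc(S(=O)(=O)c4ccccc4)ccc3C(F)(F)F)CC2)c1` gives 20 nM. Compound 3 `O=S(=O)(NC1CCN(S(=O)(=O)c2cccc(-c3nnn[nH]3)c2)CC1)c1cc(S(=O)(=O)c2ccccc2)ccc1C(F)(F)F` gives 30 nM, a value within the usual scatter of compound 2, so the two cannot be ranked. Compound 1 `CN(C)c1ccc(C(=O)N2CCC(NS(=O)(=O)c3cc(S(=O)(=O)c4ccccc4)ccc3C(F)(F)F)CC2)cc1` gives 300 nM, and the gap to compound 2 is real: a 15-fold lower number from compound 1 to compound 2 (1.18 log units; beyond the scatter). The smaller change, a 1.5-fold higher number from compound 2 to compound 3 (0.18 log units; within the scatter), shows that carboxy and 1H-tetrazol-5-yl behave alike here.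

Compound 4 `O=C(C1CCNCC1)N1CCC(NS(=O)(=O)c2cc(S(=O)(=O)c3ccccc3)ccc2C(F)(F)F)CC1` is not yet measured. It differs from compound 2 by (piperidin-4-yl)carbonyl in place of (3-carboxyphenyl)sulfonyl on an amine nitrogen in a ring. The step that bears most directly on this is the large one from compound 1 to compound 2, since both changes act on the same ring nitrogen; compound 4 gives up the (3-carboxyphenyl)sulfonyl group that accompanied the lower number in compound 2. A rise in the number beyond the scatter is therefore expected, of a size near that seen in the step from compound 1 to compound 2. The expected step is a 30-fold higher number from compound 2 to compound 4 (1.48 log units; beyond the scatter). Compound 4 is estimated at 600 nM, with a likely range from 150 nM to 2500 nM.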

Compound 4, half-maximal inhibitory concentration in the secreted frizzled-related protein 1 assay: 120 nM
Compound 4: the middle estimate sits 5.0-fold (0.70 log units) above what was measured, outside the stated range (below it).
By their numbers in the secreted frizzled-related protein 1 assay, from the lowest: compounds 2 and 3 (each within the scatter of the next); then compound 4; then compound 1.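

In the secreted frizzled-related protein 1 assay, a carbonyl-linked group on this ring nitrogen can come closer to the (3-carboxyphenyl)sulfonyl of compound 2 than compound 1 did, though a real gap remains, with a 6.0-fold higher number from compound 2 to compound 4 (0.78 log units; beyond the scatter). In the secreted frizzled-related protein 1 assay, the group on the carbonyl carbon also counts, as piperidin-4-yl in place of 4-(dimethylamino)phenyl gives a 2.5-fold lower number from compound 1 to compound 4 (0.40 log units; beyond the scatter). In a physicochemical assay for solubility, at pH 7.4 (on this read-out lower numbers stand for lower solubility and higher numbers for higher solubility), compound 2 gives > 100000 nM as a limit of the assay. In the physicochemical assay compound 4 gives > 100000 nM as a limit of the assay. In the physicochemical assay, the step from compound 2 to compound 4 cannot be read, because both values are limits of the assay: the limit of > 100000 nM in the physicochemical assay, at which 2 of the 2 values shown sit.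

As far as these compounds go, it remains open whether the nitrogen inside piperidin-4-yl contributes to the step from compound 1, and a cyclohexyl group on the same carbonyl carbon would test this. The compounds shown also do not separate the carboxy group of compound 2 from its sulfonyl link, which a 3-carboxyphenyl group on a carbonyl carbon would do.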